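This account rests on a few compounds, and the source may have more. Where it says the series, first, only, none or still open, it means among the compounds named here.

Compound 1 `CC1=CC[C@H](C(C)(C)N=C=S)CC1` gives > 100000 nM in a functional assay on NCI-H460 cells (Homo sapiens) for inhibition, read by sulforhodamine B assay, with a stated time of 48 h (a higher number here means a weaker inhibitor of growth, a lower number a stronger inhibitor of growth), which is a limit of the assay rather than a number. Compound 2 `CC1=CC[C@H](C(C)(C)NC(=S)N/N=C/c2ccc[nH]2)CC1` gives 57500 nM in this assay. Compound 3 `CC1=CC[C@H](C(C)(C)NC(=S)N/N=C(\C)c2ccccc2)CC1` gives > 100000 nM in this assay, again a limit and not a number. Within the data shown here, compound 3 thus stands at the limit of > 100000 nM in this assay, at which 2 of the 3 values shown sit, with no measured number of its own, and no step between measured compounds connects it to the others. Compound 4 `COc1ccc(/C(C)=N/NC(=S)NC(C)(C)[C@H]2CC=C(C)CC2)cc1` differs from compound 3 by methoxy in place of hydrogen on an aromatic carbon. For a change of this size no step beyond the scatter is expected in this assay, in either direction; the measured compounds offer no comparison involving a methoxy group. Compound 4 is expected at 100000 nM, between 40000 nM and 300000 nM. The expected step is a number no higher from compound 3 to compound 4 (the limit leaves the size open).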

Compound 4, concentration for total growth inhibition: > 100000 nM
Compound 4: only a limit was reported; the forecaster's own chance of this, stated with the estimate: 60%; the middle value lies on the limit itself.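

Among these compounds, compound 3 and compound 4 both give a limit, not a number, in this assay, and no step between them can be read. The compounds shown leave open whether methoxy in place of hydrogen changes growth inhibition at all.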